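Fibroblast Cytotoxicity Stays at the Limit as Bromine Shifts

The source may hold more compounds than are shown below. What is called first, only, known or untested is meant among the compounds shown, and "the series" means these compounds.

Measured compounds:
compound 1 `COC(=O)c1ccc(NCc2cncn2Cc2ccc(N)cc2)cc1-c1ccccc1`: > 10000 nM
compound 2 `COC(=O)c1ccc(NCc2cncn2Cc2cccc(Cl)c2)cc1-c1ccccc1`: > 10000 nM
compound 3 `COC(=O)c1ccc(NCc2cncn2Cc2ccc(Br)cc2)cc1-c1ccccc1`: > 10000 nM

In a toxicity assay on NIH3T3 cells (Mus musculus) for cytotoxicity, read by resazurin assay (a higher number here means that more compound is needed for the effect, a lower number that less compound is needed), compound 1 reaches only a limit of the measurement, > 10000 nM. Compound 2 likewise gives only a limit, > 10000 nM. Compound 3 also stands at a limit, > 10000 nM. All three sit at the same ceiling (the limit of > 10000 nM in this assay, at which 3 of the 3 values shown sit), so the steps a step that the two limits leave unreadable from compound 1 to compound 2, a step that the two limits leave unreadable from compound 1 to compound 3 and a step that the two limits leave unreadable from compound 2 to compound 3 cannot be sized. Compound 4 `COC(=O)c1ccc(NCc2cncn2Cc2ccccc2Br)cc1-c1ccccc1` differs from compound 3 by 2-bromophenyl in place of 4-bromophenyl on a saturated chain carbon bound to an aromatic nitrogen. Among the measured compounds shown here, no measured step reads on this change; the only guidance is that each change of the benzyl group so far left the compound at the limit. Compound 4 is therefore expected to remain at the limit, with a step that the limit leaves unreadable from compound 3 to compound 4 expected to be within scatter. The estimate for compound 4 is 20000 nM, ranging from 8000 nM to 60000 nM.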

Compound 4, half-maximal effective concentration: 10000 nM
Estimate against measurement, compound 4: 2.0-fold (0.30 log units) above, and the stated range covers the measured number.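

In this assay, among the compounds shown here, compound 4 gives 10000 nM, the first number in this set that is not a limit. With 2-bromophenyl in place of 4-bromophenyl on a saturated chain carbon bound to an aromatic nitrogen, the data show a number no higher from compound 3 to compound 4 (the limit leaves the size open). With 2-bromophenyl in place of 3-chlorophenyl at the same place, they show a number no higher from compound 2 to compound 4 (the limit leaves the size open). With 2-bromophenyl in place of 4-aminophenyl at the same place, they show a number no higher from compound 1 to compound 4 (the limit leaves the size open). These three steps cannot be read for size: the limit of > 10000 nM in this assay, at which 3 of the 4 values shown sit.

As far as these compounds go, how far compound 3 actually lies from compound 4 remains open. So does whether a methoxy group or a carboxylic acid in place of bromo on the 2-bromophenyl would give a number or return to the limit.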